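Removing an Amide Methyl in a Spirocyclic Series

The compounds below may be only part of what the source reports. "The series", "measured", "known", "first", "only" and "open" are said of these compounds alone.

The study covers three measured compounds and one still to be tested, all built on a shared core, and all assessed in a functional assay on the whole organism (strain Wister albino) for inhibition, with Rattus norvegicus as the target, read by paw edema, with a stated time of 1 h, at a dose of 50 mg/kg by the intraperitoneal route; on this read-out lower numbers stand for less inhibition and higher numbers for more inhibition at the one dose given (going by the name of the read-out). Compound 2 `CN1C(=O)[C@@]2(c3ccccc31)N(C)C[C@@H](c1ccc(F)cc1)[C@@]21Cc2ccccc2C1=O` gives 52.9% in this assay. Compound 1 `CN1C[C@@H](c2ccc(F)cc2)[C@@]2(Cc3ccccc3C2=O)[C@@]12C(=O)Nc1ccccc12` differs from compound 2 in one place: hydrogen in place of methyl on an amide-type nitrogen in a ring. In this assay compound 1 gives 40.6%, and the step is a number 12.3 percentage points lower from compound 2 to compound 1 (beyond the scatter). Compound 3 `COc1ccc([C@@H]2CN(C)[C@]3(C(=O)N(C)c4ccccc43)[C@]23Cc2ccccc2C3=O)cc1` has a different core from compound 2, and the difference is methoxy in place of fluoro on an aromatic carbon. In this assay compound 3 gives 46.9%, so the step is a number 6 percentage points lower from compound 2 to compound 3 (within the scatter). Among the compounds with values here, compound 3 and compound 1 have values close to one another, and the data give no step for that pair.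

Compound 4 `COc1ccc([C@@H]2CN(C)[C@]3(C(=O)Nc4ccccc43)[C@]23Cc2ccccc2C3=O)cc1` has not yet been measured in this assay. It differs from compound 3 by hydrogen in place of methyl on an amide-type nitrogen in a ring. The place of this change is described in exactly the same words as for the change from compound 2 to compound 1, so it is the same change, made on the other core. Since the earlier step was a number 12.3 percentage points lower from compound 2 to compound 1 (beyond the scatter), the step from compound 3 to compound 4 is expected to be of similar size, namely a number 11.9 percentage points lower from compound 3 to compound 4 (beyond the scatter). On that basis compound 4 is estimated to give 35% in this assay, with an expected range from 24% to 46%. This expectation rests on a single measured pair, compound 2 and compound 1, and the core of compound 3 may not respond in the same way.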

Compound 4, a percentage reported as inhibition, in the whole organism at one dose (the size of the read-out at that dose, not a potency): 41.2%
Beside the measured number, compound 4's estimate is 6.2 percentage points below it; the range from low to high includes it.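

On the core of compound 3, hydrogen in place of methyl on the amide-type nitrogen gives a step in this assay of a number 5.7 percentage points lower from compound 3 to compound 4 (within the scatter), and set beside the first case this change carries over from one core to the other without a difference that can be told from the scatter: the same change on two cores in this assay, a number 12.3 percentage points lower (beyond the scatter) from compound 2 to compound 1 and a number 5.7 percentage points lower (within the scatter) from compound 3 to compound 4, 6.6 percentage points apart, within the scatter of two such steps. The methoxy-for-fluoro change behaves the same way on the two cores, with a step of a number 0.6 percentage points higher from compound 1 to compound 4 (within the scatter) in the compounds that carry the amide hydrogen: the same change on two cores in this assay, a number 6 percentage points lower (within the scatter) from compound 2 to compound 3 and a number 0.6 percentage points higher (within the scatter) from compound 1 to compound 4, 6.6 percentage points apart, within the scatter of two such steps. Within the data shown here, this does not show that losing the methyl lowers the number on every core, as only the step from compound 2 to compound 1 lies beyond the scatter, and with one pair per core the agreement between two steps says nothing about the size of the change elsewhere.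

The compounds shown leave open how a longer chain such as ethyl or a benzyl group on the amide-type nitrogen would read in this whole-animal test. They also leave open what chloro, hydroxyl or an amine in place of fluoro or methoxy on the aromatic carbon would give, and how any of these compounds would read at another dose or time.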